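Methoxy for chloro repeated on a second ring

This account rests on a few compounds, and the source may have more. Where it says the series, first, only, none or still open, it means among the compounds named here.

The series shares one core and varies the group on it. Compound 1 `COc1ccc2[nH]c(-c3nc(C)no3)cc2c1`, compound 2 `Cc1noc(-c2cc3cc(Cl)ccc3[nH]2)n1` and compound 3 `Clc1ccc(-c2noc(-c3cc4ccccc4[nH]3)n2)cc1` have been measured; compound 4 `COc1ccc(-c2noc(-c3cc4ccccc4[nH]3)n2)cc1` has not. In a functional assay on MCF7 cells (Homo sapiens) for antiproliferative activity, read by WST assay, with a stated time of 72 h (on this read-out lower numbers stand for stronger inhibition and higher numbers for weaker inhibition), compound 1 gives 16700 nM. In this assay compound 2 gives 34400 nM. For compound 3 only a limit of this assay is known, and compound 3 gives > 50000 nM; this is the limit described in the limit of > 50000 nM in this assay, at which 1 of the 3 values shown sits. The difference between the cores of compound 2 and compound 3 is not broken down here.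

From compound 2 to compound 1 the change is methoxy in place of chloro on an aromatic carbon, and it produced a 2.1-fold lower number from compound 2 to compound 1 (0.31 log units; beyond the scatter). From compound 3 to compound 4 the change is of the same kind, (methoxy in place of chloro on an aromatic carbon), but the place is not the same: in compound 4 the ring is a six-membered aromatic ring of carbon only, para to a large group, whereas in compound 1 that ring is part of a fused or bridged system of two rings, meta and para to a fused ring.

Since compound 3 is known only as a limit, the step can only be gauged from that limit. In this assay, within the data shown here, compound 4 is expected to show an at least 1.2-fold lower number from compound 3 to compound 4 (0.09 log units; that floor lies within the scatter), resting on the earlier step of a 2.1-fold lower number from compound 2 to compound 1 (0.31 log units; beyond the scatter) as the single precedent for this kind of change. Compound 4 is therefore estimated at 40000 nM, with a likely range from 15000 nM to 100000 nM, and a real chance that only a limit is reported again.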

Compound 4, half-maximal inhibitory concentration: > 50000 nM
Compound 4: only a limit was reported (the forecaster's own chance of this, stated with the estimate: 45%); middle value at least 1.2-fold (0.09 log units) away from the limit.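

In this assay compound 4 gives > 50000 nM, which is a limit of the assay and not a number. Compound 3 stands at the same limit, so no step from compound 3 to compound 4 can be read: the limit of > 50000 nM in this assay, at which 2 of the 4 values shown sit.

The compounds shown leave open whether methoxy in place of chloro on this second ring changes the number at all, as it did from compound 2 to compound 1.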